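The source may report more compounds than this note shows. Statements on the series, on what has been measured and on what is new or still open speak of the compounds shown alone.

Measured compounds:
compound 1, `CCCn1c(=O)[nH]c2nc(-c3ccc(S(=O)(=O)N4CCN(c5cccc(F)c5)CC4)cc3)[nH]c2c1=O`: 0.632 nM
compound 2, `CCCn1c(=O)[nH]c2nc(-c3ccc(S(=O)(=O)N4CCN(c5ccccc5)CC4)cc3)[nH]c2c1=O`: 0.643 nM
compound 3, `CCCn1c(=O)[nH]c2nc(-c3ccc(S(=O)(=O)N4CCN(c5ccccc5C)CC4)cc3)[nH]c2c1=O`: 0.432 nM

These three values come from an assay on CHO cells for displacement of a labelled ligand from adenosine receptor A2b (Homo sapiens), read by scintillation counting, with a stated time of 75 min, in the presence of a further agent that is not named here; a higher number here means a weaker inhibitor, a lower number a stronger inhibitor. Compound 1 stands second highest of the three numbers, but its neighbours lie close: the step of a 1.0-fold higher number from compound 1 to compound 2 (0.01 log units; within the scatter) and the step of a 1.5-fold lower number from compound 1 to compound 3 (0.17 log units; within the scatter) are both within the scatter, so the three compounds cannot be told apart.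

Compound 4, `CCCn1c(=O)[nH]c2nc(-c3ccc(S(=O)(=O)N4CCN(C(C)c5ccccc5)CC4)cc3)[nH]c2c1=O`, differs from compound 1 by 1-phenylethyl in place of 3-fluorophenyl on an amine nitrogen in a ring. Among the measured compounds shown here, no measured step exchanges an aromatic ring on that nitrogen for a 1-phenylethyl group. For the measured compounds named here, the steps that bear on it, a 1.0-fold higher number from compound 1 to compound 2 (0.01 log units; within the scatter) and a 1.5-fold lower number from compound 2 to compound 3 (0.17 log units; within the scatter), only vary the ring itself, and both stay within the scatter. On that basis the change is expected to give at most a small step in this assay, with no clear direction, a 1.6-fold higher number from compound 1 to compound 4 (0.20 log units; within the scatter). Compound 4 is therefore estimated at 1 nM, expected between 0.3 nM and 3.5 nM.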

Compound 4, inhibition constant: 8.34 nM
Estimate against measurement, compound 4: 8.3-fold (0.92 log units) below; the measured number lies above the stated range.
By their numbers in this assay, from the lowest: compounds 3, 1 and 2 (each within the scatter of the next); then compound 4.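

Among the earlier compounds only the aromatic ring itself changed, and every step stayed within the scatter; this is the first change at the amine nitrogen to show a large effect in this assay, with a 13-fold higher number from compound 1 to compound 4 (1.12 log units; beyond the scatter) and a 13-fold higher number from compound 2 to compound 4 (1.11 log units; beyond the scatter) and a 19-fold higher number from compound 3 to compound 4 (1.29 log units; beyond the scatter). Both the leaving and the entering group carry one six-membered aromatic ring, so having such a ring does not by itself keep the number low. Nothing shown here explains the size of these steps.

As far as these compounds go, it remains open how a benzyl group, which lacks the methyl of 1-phenylethyl, would behave on this nitrogen, or how a pyridyl ring would compare with the phenyl rings.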